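Chloro for ethyl on the aryl ring of the diaminotriazine series

The source may report more compounds than this note shows. Statements on the series, on what has been measured and on what is new or still open speak of the compounds shown alone.

Three analogues of the shared core carry a single substituent on the pendant six-membered aromatic ring. Compound 1 `CCc1ccccc1-c1nc(N)nc(N)n1` bears an ethyl group, compound 2 `Nc1nc(N)nc(-c2cccc(C(F)(F)F)c2)n1` a trifluoromethyl group and compound 3 `Nc1nc(N)nc(-c2ccc(F)cc2)n1` a fluoro group. In a physicochemical assay for lipophilicity (on this read-out higher numbers stand for higher lipophilicity and lower numbers for lower lipophilicity), compound 1 gives 1.65, compound 2 gives 2.67 and compound 3 gives 1.61. Compound 1 thus stands second highest of the three numbers: its value and that of compound 3 lie within the usual scatter of each other, so no order between them can be claimed, whereas compound 2 sits clearly higher, beyond the scatter.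

Compound 4 `Nc1nc(N)nc(-c2ccccc2Cl)n1` is not yet measured in this assay. It differs from compound 1 in one place: chloro in place of ethyl on an aromatic carbon. The change sits on an aromatic carbon of the six-membered aromatic ring of carbon only, ortho to a group of 8 heavy atoms. Within the data shown here, no measured pair in the set isolates this exchange, so the step must be estimated.

For compound 4 a small downward step is expected, most likely within the scatter, giving an expected a number 0.20 log units lower from compound 1 to compound 4 (within the scatter). The estimate for compound 4 is 1.45, with a range from 1.05 to 1.85.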

Compound 4, partition coefficient: 1.19
Beside the measured number, compound 4's estimate is 0.26 log units above it; the measured number falls inside the stated range.
By their numbers in this assay, from the lowest: compound 4; then compounds 3 and 1 (each within the scatter of the next); then compound 2.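

Chloro in place of ethyl on an aromatic carbon, ortho to a group of 8 heavy atoms, gives the first single-place exchange that can be read in the series, and in this assay it amounts to a number 0.46 log units lower from compound 1 to compound 4 (beyond the scatter). The exchange therefore separates these two groups at this position on this read-out, even though neither group carries a ring, hydrogen-bond donors, hydrogen-bond acceptors or a net charge. Nothing at hand accounts for the direction or size of the step.

Compound 2 and compound 3 are joined to compound 4 by no single-place step, so the compounds shown leave open whether the same exchange would give a similar step elsewhere on the ring or on another substituted analogue of the shared core. Also open, from the compounds shown here alone, is how a methoxy group, an amine or a longer chain such as propyl would compare with chloro and ethyl at this same position in this assay.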